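What a carboxyethyl amide might do to compound 3

The source may report more compounds than this note shows. Statements on the series, on what has been measured and on what is new or still open speak of the compounds shown alone.

Compound 1 `CCn1c(C(=O)NCCN(C)C)ccc1C(CC)(CC)c1ccc(OCCC(O)(CC)CC)c(C)c1`: 870 nM
Compound 2 `CCn1c(C(=O)Nc2ccc(OC(F)(F)F)cc2)ccc1C(CC)(CC)c1ccc(OCCC(O)(CC)CC)c(C)c1`: > 50000 nM (a limit of the assay, not a number)
Compound 3 `CCOC(=O)CN(C)C(=O)c1ccc(C(CC)(CC)c2ccc(OCCC(O)(CC)CC)c(C)c2)n1CC`: 7140 nM

All three were tested in a functional assay on PC-3 cells (Homo sapiens) for antiproliferative activity, read by MTT assay, with a stated time of 48 h (a lower number here means a stronger inhibitor, a higher number a weaker inhibitor), and they differ only in the group on the carbonyl carbon. Compound 3 has the higher of the two true numbers, and the nearest value is reached by an 8.2-fold higher number from compound 1 to compound 3 (0.91 log units; beyond the scatter). Measured against the limit of compound 2, the step is an at least 7.0-fold lower number from compound 2 to compound 3 (0.84 log units; beyond the scatter).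

Compound 4 `CCn1c(C(=O)NC(C)C(=O)O)ccc1C(CC)(CC)c1ccc(OCCC(O)(CC)CC)c(C)c1` changes that same place: (1-carboxyethyl)amino in place of ((ethoxycarbonyl)methyl)(methyl)amino on a carbonyl carbon. Among the compounds with values here, no measured compound carries the (1-carboxyethyl)amino group, so the measured steps offer only indirect guidance. Every change here moved the number beyond the scatter, and the largest was an at least 57-fold higher number from compound 1 to compound 2 (1.75 log units; beyond the scatter). Compound 4 also lacks the (2-(dimethylamino)ethyl)amino group of compound 1, which gives 870 nM, so it is expected to stay on the weaker side in this assay. A modest move is expected, estimated as a 2.1-fold higher number from compound 3 to compound 4 (0.32 log units; beyond the scatter). The estimated value for compound 4 is 15000 nM, with an expected range from 4000 nM to 50000 nM.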

Compound 4, half-maximal inhibitory concentration: 11700 nM
For compound 4 the middle estimate is 1.3-fold (0.11 log units) above the measured one, and the stated range covers the measured number.
By their numbers in this assay, from the lowest: compound 1; then compounds 3 and 4 (each within the scatter of the next). At a limit, above all of these: compound 2.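

In this assay, the exchange of groups on this carbonyl carbon gives a 1.6-fold higher number from compound 3 to compound 4 (0.21 log units; within the scatter), so the carboxylic acid and the ethyl ester are not told apart here, although the groups differ in hydrogen-bond donors, 2 against 0. The 2-(dimethylamino)ethyl group of compound 1 remains clearly apart, with a 13-fold higher number from compound 1 to compound 4 (1.13 log units; beyond the scatter), a large step that the acid does not close. The remaining step, an at least 4.2-fold lower number from compound 2 to compound 4 (0.63 log units; beyond the scatter), starts from a limit of the assay for compound 2, not a true number: the limit of > 50000 nM in this assay, at which 1 of the 4 values shown sits.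

The ester, the amide methyl and the chain methyl all change at once. The ethyl ester of the 1-carboxyethyl group would be needed to separate them. Also open, going by these compounds, is whether a primary amine or a longer chain ending in dimethylamino would match compound 1.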